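A few compounds are considered here, and "the series" means these few. Any claim that something is new, unique, unknown or untested is made for them only; others in the source may bear on it.

Measured compounds in a functional assay on CCRF-CEM cells (Homo sapiens) for cytotoxicity; on this read-out higher numbers stand for lower toxicity in this test and lower numbers for higher toxicity in this test: compound 1 `Cc1ccc(/C=N/c2nc(NC3CC3)c3ncn(C4C=CC(CO)C4)c3n2)cc1` gives > 100000 nM, a limit of the assay. Compound 2 `CN(C)c1ccc(/C=N/c2nc(NC3CC3)c3ncn(C4C=CC(CO)C4)c3n2)cc1` gives > 100000 nM, also a limit. Compound 3 `O=[N+]([O-])c1ccc(/C=N/c2nc(NC3CC3)c3ncn(C4C=CC(CO)C4)c3n2)cc1` gives 12000 nM.

Going by the values given here, compound 3 thus holds the only number in this assay; the other two values sit at the limit of > 100000 nM in this assay, at which 2 of the 3 values shown sit. The next compound, compound 4 `COc1ccc(/C=N/c2nc(NC3CC3)c3ncn(C4C=CC(CO)C4)c3n2)cc1`, differs from compound 3 by methoxy in place of nitro on an aromatic carbon. Among the compounds with values here, the steps that bear on this are an at least 8.3-fold lower number from compound 1 to compound 3 (0.92 log units; beyond the scatter) and an at least 8.3-fold lower number from compound 2 to compound 3 (0.92 log units; beyond the scatter): both replacements of a non-nitro group by nitro gave a lower number, and both non-nitro analogues sit at the limit. Going from nitro back to methoxy, a higher number is therefore expected, probably reaching the limit again. Compound 4 is expected at 100000 nM, range 30000 nM to 300000 nM. The expected step is an 8.3-fold higher number from compound 3 to compound 4 (0.92 log units; beyond the scatter).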

Compound 4, half-maximal cytotoxic concentration: > 100000 nM
Compound 4 ended at the assay's limit; the forecaster's own chance of this, stated with the estimate: 70%; the middle value lies on the limit itself.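

In this assay, the step of an at least 8.3-fold higher number from compound 3 to compound 4 (0.92 log units; beyond the scatter) shows that a third replacement of nitro at this place, on an aromatic carbon para to a large group, also gives a higher number. Compound 3 therefore stands alone so far, while the methyl, dimethylamino and methoxy compounds share one limit: the limit of > 100000 nM in this assay, at which 3 of the 4 values shown sit. The steps among compound 1, compound 2 and compound 4 cannot be read.

Going by these compounds, how these three compare beyond the limit stays open. So does whether a low number is confined to nitro, which a nitrile or a carboxylic acid at this place would test.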